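Trimming a Dithiocarbamate Amine: From Compound 3 to Compound 4

The source may hold more compounds than are shown below. What is called first, only, known or untested is meant among the compounds shown, and "the series" means these compounds.

Of the compounds shown here, three sharing one core have been tested in a functional assay on A-375 cells (Homo sapiens) for antiproliferative activity, read by CCK-8 assay, with a stated time of 72 h, tested at 8 uM; on this read-out higher numbers stand for a stronger effect at the one concentration tested and lower numbers for a weaker effect. Compound 1 `Nc1ccccc1NC(=O)c1ccc(CSC(=S)N2CCN(C(c3ccccc3)c3ccccc3)CC2)cc1` gives 8.4%. Compound 2 `Nc1ccccc1NC(=O)c1ccc(CSC(=S)N2CCN(c3cccnc3)CC2)cc1` gives 88.8%. Compound 3 `Nc1ccccc1NC(=O)c1ccc(CSC(=S)N2CCCc3ccccc32)cc1` gives 81.5%, the second highest of the three numbers; its gap to compound 2 lies within the scatter, while its gap to compound 1 lies far beyond it, so compound 3 and compound 2 cannot be told apart, and both stand clearly above compound 1.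

Compound 4 `Nc1ccccc1NC(=O)c1ccc(CSC(=S)N2CCCC2)cc1` has not yet been measured. It differs from compound 3 in one place: pyrrolidin-1-yl in place of 1,2,3,4-tetrahydroquinolin-1-yl on a thiocarbonyl carbon. The amine on the thiocarbonyl carbon is thus smaller and lacks the aromatic ring of compound 3. Among the measured compounds, the two high values belong to amines of quite different shape, so a large drop is not the most likely outcome, but some loss cannot be excluded. The step of a number 13.5 percentage points lower from compound 3 to compound 4 (beyond the scatter) is expected to be a moderate decrease, possibly within the scatter. Compound 4 is estimated to give 68% in this assay, with a range from 40% to 90%.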

Compound 4, a percentage reported as inhibition, at one concentration (the size of the read-out at that concentration, not a potency): 89.5%
Compound 4: middle estimate off by 21.5 percentage points, on the low side; measured number inside the range.
By their numbers in this assay, from the lowest: compound 1; then compounds 3, 2 and 4 (each within the scatter of the next).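

Putting pyrrolidin-1-yl in place of 1,2,3,4-tetrahydroquinolin-1-yl on a thiocarbonyl carbon gives a number 8 percentage points higher from compound 3 to compound 4 (within the scatter) in this assay. Among these compounds, this is the first direct comparison at this position in which only the amine changes, and it shows that compound 4 keeps the effect of compound 3 without the six-membered aromatic ring, with a smaller amine of one five-membered ring. No measurement shown here explains why the two compounds cannot be told apart.

As far as these compounds go, it remains open whether the position also accepts an open-chain amine such as diethylamino, or a ring carrying oxygen such as morpholin-4-yl. A read-out at one concentration also leaves open whether compound 3 and compound 4 would separate in potency across a range of concentrations.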